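A few compounds are considered here, and "the series" means these few. Any claim that something is new, unique, unknown or untested is made for them only; others in the source may bear on it.

Measured so far:
Compound 1 `N#C/C(=C\N1CCN(C(=O)c2ccco2)C1=S)C(=O)Nc1ccc(Cl)cc1` — 19400 nM
Compound 2 `N#C/C(=C\N1CCN(C(=O)c2ccco2)C1=S)C(N)=O` — 12100 nM

In a functional assay on TK-10 cells (Homo sapiens) for inhibition, read by sulforhodamine B assay, with a stated time of 48 h (on this read-out lower numbers stand for stronger inhibition of growth and higher numbers for weaker inhibition of growth), compound 2 gives 12100 nM, the lower of the two numbers, with compound 1 within the scatter of it at 19400 nM. Compound 3 `N#C/C(=C\N1CCN(C(=O)c2ccco2)C1=S)C(=O)c1ccccc1` differs from compound 2 by phenyl in place of amino on a carbonyl carbon. Among the compounds with values here, the only measured step at this carbonyl, a 1.6-fold lower number from compound 1 to compound 2 (0.21 log units; within the scatter), was within the scatter, so a swap of the group here has so far left the number roughly unchanged. A step of similar size, not beyond the scatter, is therefore expected for a 1.2-fold higher number from compound 2 to compound 3 (0.06 log units; within the scatter). Compound 3 is expected to give about 14000 nM, between 5000 nM and 40000 nM.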

Compound 3, concentration for 50% growth inhibition: 10500 nM
Estimate against measurement, compound 3: 1.3-fold (0.12 log units) above; low and high end bracket the measured number.
By their numbers in this assay, from the lowest: compounds 3, 2 and 1 (each within the scatter of the next).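

Replacing amino with phenyl on this carbonyl carbon gives a 1.2-fold lower number from compound 2 to compound 3 (0.06 log units; within the scatter) and replacing (4-chlorophenyl)amino with phenyl gives a 1.8-fold lower number from compound 1 to compound 3 (0.27 log units; within the scatter) so all three groups tried here leave the number within the scatter. The swap to benzoyl also removes the hydrogen-bond donor of the amino group, and the number still does not move beyond the scatter. Nothing available explains this flat result. From the compounds shown here alone, whether a hydroxyl, a methyl or a morpholine on this carbonyl carbon would shift the number remains open, as does the effect of changes elsewhere on the shared core.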